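Amide series on a shared core: weak antagonists at A2b

This account rests on a few compounds, and the source may have more. Where it says the series, first, only, none or still open, it means among the compounds named here.

Measured compounds:
- compound 1 `CC(C)(C)Cn1cc2c(Cl)nc(NC(=O)c3ccccc3)nc2n1`: in a functional assay on CHO cells for antagonist activity at adenosine receptor A2b (Homo sapiens), read by 33P incorporation, with a stated time of 20 min, in the presence of a further agent that is not named here (a higher number here means a weaker inhibitor, a lower number a stronger inhibitor), compound 1 gives >= 10000 nM, which is a limit of this assay.
- compound 2 `Cn1cc2c(Cl)nc(NC(=O)c3ccc(F)cc3)nc2n1`: in this assay compound 2 gives > 20000 nM, which is a limit.
- compound 3 `CC(C)(C)Cn1cc2c(Cl)nc(NC(=O)c3ccc(C(F)(F)F)cc3)nc2n1`: in this assay compound 3 gives > 20000 nM, which is a limit.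

Compound 3 stands at the upper limit of this assay; no number is known for it, and the other two values shown are also limits, so compound 3 cannot be placed above or below either of them. For the measured compounds named here, the only measured step, a step that the two limits leave unreadable from compound 1 to compound 3, runs between two limits and has no readable size the limit of > 20000 nM in this assay, at which 2 of the 3 values shown sit (the limit of >= 10000 nM in this assay, at which 1 of the 3 values shown sits).

Compound 4 `CC(C)(C)Cn1cc2c(Cl)nc(NC(=O)c3ccc(F)cc3)nc2n1` differs from compound 3 by fluoro in place of trifluoromethyl on an aromatic carbon. Going by the values given here, the one related step, from compound 1 to compound 3, gives no size, so no direction beyond the scatter can be read for this assay from the measured compounds. The expected step that the limit leaves unreadable from compound 3 to compound 4 is therefore set as none beyond the scatter, with compound 4 most likely staying at a limit. For compound 4 the estimate in this assay is 30000 nM, with a range from 10000 nM to 100000 nM.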

Compound 4, inhibition constant: > 10000 nM
Compound 4: only a limit was reported; the forecaster's own chance of this, stated with the estimate: 85%; the middle value lies beyond the limit too.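

In this assay compound 4 gives > 10000 nM, which is a limit. For the compounds shown here, no step from compound 1, compound 2 or compound 3 to compound 4 can be read. The compounds shown leave open what numerical inhibition constant any of these amides has, and whether the fluoro, trifluoromethyl or tert-butyl changes shift it at all.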